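Notes on the side chain step to compound 4

The compounds below may be only part of what the source reports. "The series", "measured", "known", "first", "only" and "open" are said of these compounds alone.

Measured so far in an ADME assay on microsomes from liver (Mus musculus) for metabolic stability, read by LC-MS, tested at 1 uM; on this read-out lower numbers stand for slow clearance and higher numbers for fast clearance:
- compound 1 `c1cc([C@H]2CC[C@]3(CC2)OOC2(O3)C3CC4CC(C3)CC2C4)ccc1OCCC1CCNCC1`: 7 mL.min-1.g-1
- compound 2 `c1cc([C@H]2CC[C@]3(CC2)OOC2(O3)C3CC4CC(C3)CC2C4)ccc1OC1CCNCC1`: 10 mL.min-1.g-1
- compound 3 `N[C@H]1CC[C@@H](Oc2ccc([C@H]3CC[C@]4(CC3)OOC3(O4)C4CC5CC(C4)CC3C5)cc2)CC1`: < 7 mL.min-1.g-1, a limit and not a number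

Compound 3 gives no number, only (the limit of < 7 mL.min-1.g-1 in this assay, at which 1 of the 3 values shown sits). The next structure is compound 4 `CC1(C)CC(O)(COc2ccc([C@H]3CC[C@]4(CC3)OOC3(O4)C4CC5CC(C4)CC3C5)cc2)CC(C)(C)N1`, and the change is (4-hydroxy-2,2,6,6-tetramethylpiperidin-4-yl)methyl in place of 4-aminocyclohexyl on an oxygen on an aromatic ring. The group on the oxygen is thus replaced once more.

For the measured compounds named here, three measured steps bear on this, all at that same place: a 1.4-fold higher number from compound 1 to compound 2 (0.15 log units; within the scatter), a number no higher from compound 1 to compound 3 (the limit leaves the size open) and an at least 1.4-fold lower number from compound 2 to compound 3 (0.15 log units; that floor lies within the scatter). None of them is shown to go beyond the scatter, although the size of the second cannot be read. The entering group differs from all three groups measured so far, so a wide range is kept.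

No step beyond the scatter is expected in this assay, and the estimated step is an at least 1.4-fold higher number from compound 3 to compound 4 (0.15 log units; that floor lies within the scatter). For compound 4 the expected value is 10 mL.min-1.g-1. The estimated range for compound 4 runs from 6 mL.min-1.g-1 to 25 mL.min-1.g-1.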

Compound 4, intrinsic clearance in microsomes: < 7 mL.min-1.g-1
Compound 4 ended at the assay's limit; the forecaster's own chance of this, stated with the estimate: 25%; at least 1.4-fold (0.15 log units) between middle value and limit.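

In this assay, a side chain with more heavy atoms and a second hetero atom, (4-hydroxy-2,2,6,6-tetramethylpiperidin-4-yl)methyl, is accepted on the oxygen on an aromatic ring in place of 4-aminocyclohexyl with a step that the two limits leave unreadable from compound 3 to compound 4 and the result for compound 4 is a limit, not a number: the limit of < 7 mL.min-1.g-1 in this assay, at which 2 of the 4 values shown sit.

The one readable new step is an at least 1.4-fold lower number from compound 2 to compound 4 (0.15 log units; that floor lies within the scatter), so this change is not shown to go beyond the scatter. Neither a number no higher from compound 1 to compound 4 (the limit leaves the size open) nor the step given first can be read.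

On these data alone, the actual values of compound 3 and compound 4 stay open, so no order between them can be given. Also open, as far as these compounds go, is which part of the new group matters, a question that (4-hydroxypiperidin-4-yl)methyl and (2,2,6,6-tetramethylpiperidin-4-yl)methyl on the same oxygen would address.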